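Ring Size on the Amine: Compound 3 to Compound 4

A few compounds are considered here, and "the series" means these few. Any claim that something is new, unique, unknown or untested is made for them only; others in the source may bear on it.

Of the compounds shown here, three built on one shared core have been measured in a functional assay on the whole organism with Rattus norvegicus as the target, in the maximal electroshock model; on this read-out lower numbers stand for an effect already at smaller amounts and higher numbers for an effect only at larger amounts of compound. Compound 1 `CNc1ncnc2c1ncn2Cc1ccc(N)cc1` gives 25 mg/kg in this assay, and compound 2 `CNc1ncnc2c1ncn2Cc1c(F)cccc1Cl` gives 12.5 mg/kg. Compound 3 `Fc1ccccc1Cn1cnc2c(NC3CCC3)ncnc21` gives 33 mg/kg, the highest of the three numbers; its gap to compound 1 lies within the scatter, while compound 2 stands beyond it with the lower number. Compound 4 `Fc1ccccc1Cn1cnc2c(NC3CC3)ncnc21` differs from compound 3 in a single place: cyclopropyl in place of cyclobutyl on a nitrogen on an aromatic ring. Among the measured compounds shown here, no measured pair shows this change, so nothing among the three compounds tells how large it is. A step of a 1.1-fold lower number from compound 3 to compound 4 (0.04 log units; within the scatter) is expected, within the scatter in either direction. Compound 4 is therefore estimated at 30 mg/kg, with a range from 15 mg/kg to 60 mg/kg.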

Compound 4, dose for half-maximal effect: 5 mg/kg
Beside the measured number, compound 4's estimate is 6.0-fold (0.78 log units) above it; the measured number lies below the stated range.
By their numbers in this assay, from the lowest: compound 4; then compounds 2, 1 and 3 (each within the scatter of the next, the first and the last beyond it).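

The cyclobutylamino to cyclopropylamino change shows that this position is sensitive to ring size: in this assay, cyclopropyl in place of cyclobutyl on a nitrogen on an aromatic ring gives a 6.6-fold lower number from compound 3 to compound 4 (0.82 log units; beyond the scatter). Among the compounds shown here, this is the first step that isolates this place, and it lies beyond the scatter. No supporting measurement bears on why the step has this size.

On these data alone, whether a cyclopentyl ring or an isopropyl group on this nitrogen would fall in line remains open. One pair also cannot tell whether the step holds with other groups elsewhere on the shared core.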